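The source may report more compounds than this note shows. Statements on the series, on what has been measured and on what is new or still open speak of the compounds shown alone.

Measured so far in a functional assay on NCI-H226 cells (Homo sapiens) for inhibition, read by MTT assay, with a stated time of 72 h; on this read-out lower numbers stand for stronger inhibition of growth and higher numbers for weaker inhibition of growth:
compound 1 `CCc1nc(C(=O)OC)nn1-c1ccc(F)cc1` gives 71300 nM
compound 2 `COC(=O)c1nc(C(C)C)n(-c2ccc(F)cc2)n1` gives 6170 nM
compound 3 `COC(=O)c1nc(-c2ccc[nH]2)n(-c2ccc(C(F)(F)F)cc2)n1` gives 5650 nM

The one counted step among these is a 12-fold lower number from compound 1 to compound 2 (1.06 log units; beyond the scatter), made by methyl in place of hydrogen on a saturated chain carbon bound to an aromatic carbon and a saturated chain carbon. Compound 3 and compound 2 give numbers within the scatter of each other; compound 3 against compound 1 is a gap beyond the scatter. The difference between the cores of compound 1 and compound 3 is not broken down here.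

Compound 4 `CCOC(=O)c1nc(-c2ccc[nH]2)n(-c2ccc(C(F)(F)F)cc2)n1` is still to be measured in this assay. It differs from compound 3 by methyl in place of hydrogen on a saturated chain carbon bound to an oxygen next to a carbonyl group. This is the same kind of change as from compound 1 to compound 2, but not the same: there the place was on a saturated chain carbon bound to an aromatic carbon and a saturated chain carbon, here it is on a saturated chain carbon bound to an oxygen next to a carbonyl group. Going by the values given here, only one step of this kind is measured, and at a different place, so its full size is not expected to carry over. Compound 4 is expected to give about 4500 nM, with a likely range from 1500 nM to 15000 nM. The expected step of a 1.3-fold lower number from compound 3 to compound 4 (0.10 log units; within the scatter) is therefore estimated smaller than a 12-fold lower number from compound 1 to compound 2 (1.06 log units; beyond the scatter), and within the scatter of the number for compound 3.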

Compound 4, concentration for 50% growth inhibition: 5610 nM
The estimate for compound 4 lay 1.2-fold (0.10 log units) below the measured number; the measured number falls inside the stated range.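

In this assay the change from methoxycarbonyl to ethoxycarbonyl gives a 1.0-fold lower number from compound 3 to compound 4 (0.00 log units; within the scatter) and so leaves the growth-inhibition number of this pair within the scatter. Methyl in place of hydrogen therefore does not carry one size of step from one core to the other in this series: the same change on two cores in this assay, a 12-fold lower number (1.06 log units; beyond the scatter) from compound 1 to compound 2 and a 1.0-fold lower number (0.00 log units; within the scatter) from compound 3 to compound 4, 11-fold (1.06 log units) apart, beyond the scatter of two such steps

This does not show whether the core or the place accounts for the gap, since the two steps differ in both and each is a single pair; no rule for other cores follows from them. Still open, on these data alone, is whether the step seen on the core of compound 1 would appear on the core of compound 3 at the same saturated chain carbon, and whether ethoxycarbonyl would leave the number on the core of compound 1 within the scatter. Also open, as far as these compounds go, is how propoxycarbonyl, a carboxylic acid or a primary amide in place of ethoxycarbonyl would read in this assay on the core of compound 4.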